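Piperidine for morpholine on the thiocarbonyl carbon of compound 3

The source may report more compounds than this note shows. Statements on the series, on what has been measured and on what is new or still open speak of the compounds shown alone.

Three compounds of the series have numbers in a functional assay on MDA-MB-435S cells (Homo sapiens) for antiproliferative activity, read by MTT assay, with a stated time of 72 h (on this read-out lower numbers stand for stronger inhibition and higher numbers for weaker inhibition), so far. Compound 1 `Cc1ccc2c(=O)c(CSC(=S)N3CCCCC3)coc2c1` gives 1700 nM. Compound 2 `CCOC(=O)c1cc(=O)c2cc(CSC(=S)N(C)c3ccccc3)ccc2o1` gives 13500 nM. Compound 3 `O=c1c(CSC(=S)N2CCOCC2)coc2cc(Cl)ccc12` gives 600 nM, the lowest of the three; compound 1 stands nearest to it, at a gap beyond the scatter, and compound 2 furthest, at a much wider gap. No pair among these three differs in one place only, so no single change can be read from them.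

Compound 4 `O=c1c(CSC(=S)N2CCCCC2)coc2cc(Cl)ccc12` is not yet measured. It differs from compound 3 in one place: piperidin-1-yl in place of morpholin-4-yl on a thiocarbonyl carbon. Compound 1 carries the same piperidin-1-yl group on a different core, so its value of 1700 nM cannot be tied to the ring alone. On this basis no step beyond the scatter is expected from compound 3 to compound 4 in this assay, with the uncertainty leaning towards a somewhat higher number. For compound 4 the estimate is 750 nM (250 nM to 2200 nM), which means an expected step of a 1.3-fold higher number from compound 3 to compound 4 (0.10 log units; within the scatter).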

Compound 4, half-maximal inhibitory concentration: 240 nM
For compound 4 the middle estimate is 3.1-fold (0.49 log units) above the measured one; the whole stated range lies above it.
By their numbers in this assay, from the lowest: compound 4; then compound 3; then compound 1; then compound 2.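

In this assay, the group on the thiocarbonyl carbon matters: piperidin-1-yl in place of morpholin-4-yl gives a 2.5-fold lower number from compound 3 to compound 4 (0.40 log units; beyond the scatter), so the ring oxygen of morpholin-4-yl is not required for activity in this series. With piperidin-1-yl held constant, chloro in place of methyl on an aromatic carbon gives a 7.1-fold lower number from compound 1 to compound 4 (0.85 log units; beyond the scatter), which separates the contribution of that aromatic substituent from the contribution of the amine ring. Nothing in the available data accounts for either step.

As far as these compounds go, it remains open whether an open-chain diethylamino group or a piperazin-1-yl ring on the thiocarbonyl carbon would extend or reverse the piperidin-1-yl step. Also open, from the compounds shown here alone, is whether fluoro or bromo on the aromatic carbon would behave as chloro does, and whether the morpholin-4-yl to piperidin-1-yl step would hold with methyl there.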